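Replacing methoxyphenyl with dimethylaminophenyl on the shared core

The source may hold more compounds than are shown below. What is called first, only, known or untested is meant among the compounds shown, and "the series" means these compounds.

Three compounds with one shared core have been examined in a functional assay on WI-38 VA13 cells (Homo sapiens) for cytotoxicity; on this read-out lower numbers stand for an effect already at smaller amounts and higher numbers for an effect only at larger amounts of compound. Compound 2 `Cc1c(C(=O)c2ccc(F)c(F)c2)oc2cc(-c3ccccc3)cc(O)c12` gives 0.4 ug/mL. Compound 3 `COc1ccccc1C(=O)c1oc2cc(-c3ccccc3)cc(O)c2c1C` gives 0.09 ug/mL, the lowest of the two numbers, and the step of a 4.4-fold lower number from compound 2 to compound 3 (0.65 log units; beyond the scatter) lies beyond the scatter. Compound 1 `Cc1c(C(=O)c2ccc(CN(C)C)cc2)oc2cc(-c3ccccc3)cc(O)c12` reaches only a limit of the assay, > 4 ug/mL. Compound 4 `Cc1c(C(=O)c2ccc(N(C)C)cc2)oc2cc(-c3ccccc3)cc(O)c12` has not yet been measured. It differs from compound 3 in one place: 4-(dimethylamino)phenyl in place of 2-methoxyphenyl on a carbonyl carbon. Among the compounds with values here, no measured step covers this exact exchange; the only step available, a 4.4-fold lower number from compound 2 to compound 3 (0.65 log units; beyond the scatter), shows that exchanging the ring on the carbonyl carbon moves the read-out by a modest amount. Compound 1, whose structure stands beside it, sits at the limit of > 4 ug/mL in this assay, at which 1 of the 3 values shown sits, and is the nearest guide for a ring of this kind. A higher number than that of compound 3 is therefore expected, with a real chance that only a limit is reported. Compound 4 in this assay is estimated at 1 ug/mL, with a range from 0.2 ug/mL to 5 ug/mL. The step expected is an 11-fold higher number from compound 3 to compound 4 (1.05 log units; beyond the scatter).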

Compound 4, half-maximal effective concentration: > 4 ug/mL
Compound 4: only a limit was reported (the forecaster's own chance of this, stated with the estimate: 35%); middle value at least 4.0-fold (0.60 log units) away from the limit.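

On the ring attached to the carbonyl carbon, 4-(dimethylamino)phenyl in place of 2-methoxyphenyl gives a much larger change in this assay than the modest ring exchange seen earlier: an at least 44-fold higher number from compound 3 to compound 4 (1.64 log units; beyond the scatter). Set against 3,4-difluorophenyl, the same group also gives a change beyond the scatter, an at least 10-fold higher number from compound 2 to compound 4 (1.00 log units; beyond the scatter), and both of these steps are minimum sizes, as the value of compound 4 is a limit of the assay. The step between compound 1 and compound 4 cannot be read, and the two compounds now share this limit: the limit of > 4 ug/mL in this assay, at which 2 of the 4 values shown sit.

The compounds shown leave open whether this limit goes with the dimethylamino group or with other nitrogen-containing groups. A ring carrying a morpholine or a carboxylic acid at this position could help separate these possibilities.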